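A few compounds are considered here, and "the series" means these few. Any claim that something is new, unique, unknown or untested is made for them only; others in the source may bear on it.

Measured in an ADME assay on microsomes from liver (Homo sapiens) for metabolic stability, read by LC-MS, with NADPH named in the record, with a stated time of 60 min, tested at 1 uM, in the absence of a further agent (on this read-out lower numbers stand for a less stable compound and higher numbers for a more stable compound), as percent of compound remaining:

compound 1 `COc1ccc(-c2c(C)nc3c(N4CC[C@@H](NC(C)=O)C4)cc(C)nn23)cc1OC` gives > 95% as a limit
compound 2 `COc1cc(-c2c(C)nc3c(N4CC[C@@H](NC(C)=O)C4)cc(C)nn23)cc(OC)c1OC` gives > 95% as a limit
compound 3 `CC(=O)N[C@@H]1CCN(c2cc(C)nn3c(-c4ccc5cc[nH]c5c4)c(C)nc23)C1` gives > 95% as a limit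

Compound 1 stands at > 95% as a limit and not as a number. The wider set offers only the limit of > 95% in this assay, at which 3 of the 3 values shown sit, as its evidence. Compound 4 `COc1ccc(-c2c(C)nc3c(N4CC[C@@H](NC(=O)OCc5ccccc5)C4)cc(C)nn23)cc1OC` differs from compound 1 by the change benzyloxy in place of methyl on a carbonyl carbon and acetamido thereby becomes (benzyloxycarbonyl)amino. Among the compounds with values here, two measured steps bear on this only loosely, namely a step that the two limits leave unreadable from compound 1 to compound 2 and a step that the two limits leave unreadable from compound 1 to compound 3 with no size to carry over. Both of those changes fall on an aromatic carbon and not on a carbonyl carbon. The expectation therefore rests on the structural change alone. A downward move is expected in this assay with wide uncertainty, and its estimated size is a number at least 25 percentage points lower from compound 1 to compound 4 (beyond the scatter) on this read-out. For compound 4 the expected value is 70% with an estimated range from 35% to 95% in the measurement to come.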

Compound 4, percent of the compound remaining: > 95%
Compound 4: no number, only a limit (the forecaster's own chance of this, stated with the estimate: 25%); at least 25 percentage points between middle value and limit.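

Compound 1 and compound 4 are both given only as limits in this assay, and the step between them cannot be read. The compounds shown leave open whether any of these changes alters the percent of compound remaining, as every value sits at one shared mark: the limit of > 95% in this assay, at which 4 of the 4 values shown sit.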